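Amide nitrogen variation on the shared core: compound 4

This account rests on a few compounds, and the source may have more. Where it says the series, first, only, none or still open, it means among the compounds named here.

Measured in a functional assay on L02 cells (Homo sapiens) for inhibition, read by MTT assay, with a stated time of 48 h; on this read-out lower numbers stand for stronger inhibition and higher numbers for weaker inhibition:
compound 1 `COc1ccc2c(=O)c(/C=C/C(=O)Nc3ccccc3)coc2c1`, an assay limit of > 200000 nM.
compound 2 `COc1ccc2c(=O)c(/C=C/C(=O)NCc3ccc(F)cc3)coc2c1`, an assay limit of > 200000 nM.
compound 3 `COc1ccc2c(=O)c(/C=C/C(=O)NCc3ccccc3)coc2c1`, an assay limit of > 200000 nM.

Compound 3 stands, like both others, at the limit of > 200000 nM in this assay, at which 3 of the 3 values shown sit, so no order among the three can be read. The steps a step that the two limits leave unreadable from compound 1 to compound 3, a step that the two limits leave unreadable from compound 1 to compound 2 and a step that the two limits leave unreadable from compound 2 to compound 3 are therefore all unreadable. Compound 4 `COc1ccc2c(=O)c(/C=C/C(=O)Nc3ccccc3C)coc2c1` differs from compound 3 by 2-methylphenyl in place of benzyl on an amide-type nitrogen. A phenyl on this nitrogen is already present in compound 1, which sits at the limit > 200000 nM. No step beyond the scatter is expected in this assay, and most likely only a limit again. Compound 4 is estimated at 200000 nM, within 100000 nM to 400000 nM. This corresponds to an expected step of a number no higher from compound 3 to compound 4 (the limit leaves the size open).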

Compound 4, half-maximal inhibitory concentration: > 200000 nM
Compound 4: no number, only a limit; the forecaster's own chance of this, stated with the estimate: 85%; the middle value sits exactly at the limit.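

No new step can be read between compound 4 and compound 1, compound 2 or compound 3, since each value is only a limit: the limit of > 200000 nM in this assay, at which 4 of the 4 values shown sit.

From the compounds shown here alone, whether any group on the amide nitrogen of the shared core gives a true number remains open.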